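Swapping the aryl group on a shared oxime core

The source may hold more compounds than are shown below. What is called first, only, known or untested is meant among the compounds shown, and "the series" means these compounds.

Compound 1 `NS(=O)(=O)CC(=O)NCCSc1nonc1/C(=N/O)Nc1cccc(C(F)F)c1` was tested in an assay for inhibition of Indoleamine 2,3-dioxygenase 1 (Homo sapiens), read by fluorescence, with a stated time of 1 h (a lower number here means a stronger inhibitor, a higher number a weaker inhibitor), and gave 130 nM. Two related compounds frame that number: compound 2 `COc1nonc1/C(=N/O)Nc1ccc(F)c(Br)c1` gives 230 nM in this assay, and compound 3 `O=C(NCCSc1nonc1/C(=N/O)Nc1ccc(F)c(C(F)F)c1)C1CS(=O)(=O)C1` gives 70 nM; the number for compound 1 sits between these two, and both gaps lie within the usual scatter. Compound 4 `NS(=O)(=O)CC(=O)NCCSc1nonc1/C(=N/O)Nc1ccc(F)c(Br)c1` keeps the side chain of compound 1 and changes only the aryl group: 3-bromo-4-fluorophenyl in place of 3-(difluoromethyl)phenyl on an amine nitrogen. No direct comparison of this exact change exists among the measured compounds, and compound 2 already carries the same bromo-fluoro aryl group at a similar potency. The step from compound 1 to compound 4 is therefore expected to be small, a 1.2-fold higher number from compound 1 to compound 4 (0.06 log units; within the scatter), with no direction beyond the scatter. Compound 4 is estimated at 150 nM, within a range from 60 nM to 400 nM.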

Compound 4, half-maximal inhibitory concentration: 71 nM
Beside the measured number, compound 4's estimate is 2.1-fold (0.32 log units) above it; the measured number falls inside the stated range.
By their numbers in this assay, from the lowest: compounds 3, 4, 1 and 2 (each within the scatter of the next, the first and the last beyond it).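

With the side chain of compound 1 held fixed, the two aryl groups can be compared directly on the amine nitrogen in this assay, with a 1.8-fold lower number from compound 1 to compound 4 (0.26 log units; within the scatter), so 3-bromo-4-fluorophenyl and 3-(difluoromethyl)phenyl stand within the usual scatter of each other. Nothing available here explains this closeness.

Going by these compounds, it remains open whether an unsubstituted phenyl or a pyridine ring on the same nitrogen would also stay within the scatter. On these data alone, it is also open whether this swap would give a similar result with a different side chain, such as a longer chain ending in a carboxylic acid.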